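Swapping Methyl Positions on a Cyclohexyl Ether

The compounds below may be only part of what the source reports. "The series", "measured", "known", "first", "only" and "open" are said of these compounds alone.

Three ether compounds have been tested in an ADME assay on MDBK cells (Bos taurus) for cytotoxicity, read by MTT assay; on this read-out lower numbers stand for higher toxicity in this test and higher numbers for lower toxicity in this test. Compound 1 `CCCCC1CCC(OCCCCCCN2C[C@H](O)[C@@H](O)[C@H](O)[C@H]2CO)CC1` gives 190000 nM. Compound 2 `CC1CCCC(OCCCCCCN2C[C@H](O)[C@@H](O)[C@H](O)[C@H]2CO)C1C` gives only a limit of the test, > 500000 nM. Compound 3 `OC[C@@H]1[C@@H](O)[C@H](O)[C@@H](O)CN1CC/C=C/CCOc1cc(F)ccc1F` likewise gives only a limit, > 500000 nM. Compound 2 therefore stands at the limit of > 500000 nM in this assay, at which 2 of the 3 values shown sit, so its true value is not known, only that it is not more toxic than this. Going by these compounds, compound 4 `CC1CCC(OCCCCCCN2C[C@H](O)[C@@H](O)[C@H](O)[C@H]2CO)CC1C` is untested; it differs from compound 2 by a group of 8 heavy atoms (8 carbon; one six-membered non-aromatic ring of carbon only) in place of a group of 8 heavy atoms (8 carbon; one six-membered non-aromatic ring of carbon only), on an oxygen on a saturated carbon. The two rings hold the same atoms joined differently, and no step beyond the usual scatter in this assay is expected, in either direction. Compound 4 is expected to give 450000 nM, between 150000 nM and 1000000 nM, most likely again reported only as a limit. The expected step from compound 2 to compound 4 is an at least 1.1-fold lower number from compound 2 to compound 4 (0.04 log units; that floor lies within the scatter).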

Compound 4, half-maximal cytotoxic concentration: > 500000 nM
Compound 4: only a limit was reported; the forecaster's own chance of this, stated with the estimate: 70%; middle value at least 1.1-fold (0.04 log units) from the limit.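

Among the compounds shown here, compound 2 and compound 4 each give only a limit of the test, so no step between them can be read. Going by these compounds, whether their two rings differ in toxicity at all stays open.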